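This account rests on a few compounds, and the source may have more. Where it says the series, first, only, none or still open, it means among the compounds named here.

In a functional assay on KB cells (Homo sapiens) for cytotoxicity (on this read-out lower numbers stand for an effect already at smaller amounts and higher numbers for an effect only at larger amounts of compound), compound 1 `COc1cc(-c2cc(=O)c3c(OC)c(OC)c(OC)c(OC)c3o2)cc(OC)c1OC` gives 0.5 ug/mL, the lowest number among the compounds that gave a number. The nearest is compound 3 `COc1ccc(-c2cc(=O)c3ccccc3o2)c(OC)c1OC`, which in this assay gives 13 ug/mL; the gap between the two is beyond the usual scatter. Compound 2 `O=c1c(Cl)c(-c2ccccc2)oc2ccc(Cl)cc12` sits at the limit of > 100 ug/mL in this assay, at which 1 of the 3 values shown sits, which is a limit of this assay and not a number, so in this assay compound 2 gives > 100 ug/mL only as a limit.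

Compound 4 `COc1cc(OC)cc(-c2cc(=O)c3c(OC)c(OC)c(OC)c(OC)c3o2)c1` differs from compound 1 in one place: hydrogen in place of methoxy on an aromatic carbon. For the measured compounds named here, no measured pair shows this exact change, so the size of the step can only be guessed. Compared with compound 1, compound 3 carries fewer methoxy groups but differs in several places, and compound 3 gives the higher number 13 ug/mL, which suggests that removing a methoxy tends to raise the number. In this assay compound 4 is therefore expected to give 2 ug/mL, within a range of 0.5 ug/mL to 8 ug/mL. The expected step is a 4.0-fold higher number from compound 1 to compound 4 (0.60 log units; beyond the scatter), a rise that may be beyond the scatter.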

Compound 4, concentration for half-maximal effect: 3 ug/mL
For compound 4 the middle estimate is 1.5-fold (0.18 log units) below the measured one; measured number inside the range.
By their numbers in this assay, from the lowest: compound 1; then compound 4; then compound 3. At a limit, above all of these: compound 2.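

For the compounds shown here, this is the first pair that differs in a single place. In this assay, replacing the methoxy with hydrogen gives a 6.0-fold higher number from compound 1 to compound 4 (0.78 log units; beyond the scatter), so the methoxy at this position, para to a large group, matters for this read-out on its own. The earlier compounds differ from one another in several places and could not tie a change in the number to one group, and nothing shown here explains why this step occurs.

As far as these compounds go, it remains open whether an amine, a hydroxyl or a longer chain such as ethoxy on this carbon would keep the number close to that of compound 1 or shift it further. From the compounds shown here alone, it is also open whether removing a methoxy elsewhere on the core would bring a step of similar size.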